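Methylating the Hydroxy Group of an Acrylamide Aniline

The compounds below may be only part of what the source reports. "The series", "measured", "known", "first", "only" and "open" are said of these compounds alone.

Compound 3 `C=CC(=O)Nc1cccc(C(O)CCCC)c1` returns, in a functional assay on HT-29 cells (Homo sapiens) for antiproliferative activity, with a stated time of 48 h (a higher number here means a weaker inhibitor, a lower number a stronger inhibitor), only a limit, > 100000 nM. Compound 1 `CCCCC(OC)c1cccc(NC(=O)NC(=O)CCl)c1` gives 10000 nM in this assay. Compound 2 `CCCCC(OC)c1cccc(NC(=O)CCCl)c1` likewise reaches only a limit, > 100000 nM, in this assay. Among the numbers shown stands (the limit of > 100000 nM in this assay, at which 2 of the 3 values shown sit), and compound 3 is one of those two. Compound 4 `C=CC(=O)Nc1cccc(C(CCCC)OC)c1` differs from compound 3 by methyl in place of hydrogen on an oxygen on a saturated carbon. For the measured compounds named here, the single measured step, an at least 10-fold higher number from compound 1 to compound 2 (1.00 log units; beyond the scatter), alters the linker rather than this oxygen, so no measured step bears on the hydroxy-to-methoxy change, and a step of no size beyond the scatter is expected, a number no higher from compound 3 to compound 4 (the limit leaves the size open). Compound 4 is therefore estimated at 100000 nM, in a range from 30000 nM to 300000 nM.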

Compound 4, half-maximal inhibitory concentration: 40000 nM
Beside the measured number, compound 4's estimate is 2.5-fold (0.40 log units) above it; measured number inside the range.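

In this assay methyl in place of hydrogen on this oxygen gives an at least 2.5-fold lower number from compound 3 to compound 4 (0.39 log units; beyond the scatter) and so yields a number where the hydroxy compound held only a limit. With the methoxy kept, the group on the carbonyl carbon also matters: vinyl in place of 2-chloroethyl gives an at least 2.5-fold lower number from compound 2 to compound 4 (0.39 log units; beyond the scatter) and vinyl in place of ((chloromethyl)carbonyl)amino gives a 4.0-fold higher number from compound 1 to compound 4 (0.60 log units; beyond the scatter) in the opposite direction.

On these data alone, whether an ethoxy group or an amine on this saturated carbon would lower the number further stays open. Compound 3 stands only at a limit of the assay, so the true size of the hydroxy-to-methoxy step also stays open: the limit of > 100000 nM in this assay, at which 2 of the 4 values shown sit.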